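A few compounds are considered here, and "the series" means these few. Any claim that something is new, unique, unknown or untested is made for them only; others in the source may bear on it.

In an ADME assay on the whole organism (Rattus norvegicus) for pharmacokinetics, read by LC-MS (a higher number here means faster removal of the compound, a lower number slower removal), compound 1 (`Cc1ccc(-c2c3c(nc(C)c2C(OC(C)(C)C)C(=O)O)CCN(Cc2ccccc2-c2ccccc2)C3)cc1`) gives 24 mL/min/kg and compound 2 (`Cc1ccc(-c2c3c(nc(C)c2[C@H](OC(C)(C)C)C(=O)O)CCN(C(=O)OCc2ccccc2)C3)cc1`) gives 118 mL/min/kg as the higher of the two numbers, a gap beyond the usual scatter. Compound 3 (`Cc1ccc(-c2c3c(nc(C)c2[C@H](OC(C)(C)C)C(=O)O)CCN(C(=O)CCc2ccccc2)C3)cc1`) differs from compound 2 in one place (phenethyl in place of benzyloxy on a carbonyl carbon): phenethyl in place of benzyloxy on a carbonyl carbon. Going by the values given here, no measured pair shows this change alone, so only a modest fall in this assay is expected, with the estimated step (a 1.6-fold lower number from compound 2 to compound 3 (0.20 log units; within the scatter)) probably staying within the scatter. Compound 3 is estimated at 75 mL/min/kg in a range from 30 mL/min/kg to 150 mL/min/kg for its clearance.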

Compound 3, clearance: 163 mL/min/kg
Estimate against measurement, compound 3: 2.2-fold (0.34 log units) below; the whole stated range lies below it.
By their numbers in this assay, from the lowest: compound 1; then compounds 2 and 3 (each within the scatter of the next).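

Going by these compounds alone, this is the first comparison that changes one place only. On a carbonyl carbon bonded to an amide-type nitrogen in a ring, putting phenethyl in place of benzyloxy swaps the oxygen-bearing group for an all-carbon one of the same size, and in this assay this gives a 1.4-fold higher number from compound 2 to compound 3 (0.14 log units; within the scatter). At this position, then, the swap leaves clearance within the usual scatter, and nothing available here offers a reason for that. Still open, on these data alone, is whether a shorter chain, a longer chain or an amine on this carbonyl carbon would move clearance beyond the scatter.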